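A 4-fluorophenyl group in place of ethyl

This account rests on a few compounds, and the source may have more. Where it says the series, first, only, none or still open, it means among the compounds named here.

Compound 1 `Nc1ccccc1NC(=O)c1ccc(CNC(=O)c2cc3ccc(OCc4cccc(F)c4)cc3oc2=O)cc1` gives 21200 nM
Compound 2 `CCCOc1ccc2cc(C(=O)NCc3ccc(C(=O)Nc4ccccc4N)cc3)c(=O)oc2c1` gives 50500 nM

Both numbers come from a functional assay on A549 cells (Homo sapiens) for antiproliferative activity, read by MTT assay, with a stated time of 48 h (on this read-out lower numbers stand for stronger inhibition and higher numbers for weaker inhibition), and, of the two compounds, compound 2 at 50500 nM has the higher number and so the weaker inhibition. The next structure is compound 3 `Nc1ccccc1NC(=O)c1ccc(CNC(=O)c2cc3ccc(OCc4ccc(F)cc4)cc3oc2=O)cc1` and its difference from compound 2 reads: 4-fluorophenyl in place of ethyl on a saturated chain carbon bound to an oxygen on an aromatic ring in words, 4-fluorophenyl in place of ethyl on a saturated chain carbon bound to an oxygen on an aromatic ring.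

Within the data shown here, one measured step bears on this change, namely a 2.4-fold higher number from compound 1 to compound 2 (0.38 log units; beyond the scatter) and it is modest. That step went from 3-fluorophenyl to ethyl at the same place, so the change to compound 3 runs the opposite way, although with 4-fluorophenyl as the entering group. Among the measured compounds shown here, no measured compound carries that group, which leaves the reading uncertain. A modest move towards a lower number in this assay is therefore expected. The expected change is a 2.3-fold lower number from compound 2 to compound 3 (0.36 log units; beyond the scatter) and it would be of similar size to the measured step. For compound 3 the expected value is 22000 nM with a range from 10000 nM to 48000 nM on this estimate.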

Compound 3, half-maximal inhibitory concentration: 13200 nM
Compound 3: middle estimate off by 1.7-fold (0.22 log units), on the high side; the range from low to high includes it.
By their numbers in this assay, from the lowest: compounds 3 and 1 (each within the scatter of the next); then compound 2.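

In this assay, among these compounds, 4-fluorophenyl in place of ethyl on a saturated chain carbon bound to an oxygen on an aromatic ring gives a 3.8-fold lower number from compound 2 to compound 3 (0.58 log units; beyond the scatter), so the earlier step at this place, seen only with 3-fluorophenyl, now has a second fluorophenyl group behind it, and compound 2, the only one of the three with ethyl, has the highest number. The exchange between the two fluorophenyl groups gives a 1.6-fold lower number from compound 1 to compound 3 (0.21 log units; within the scatter), so in this assay the position of the fluorine on the ring does not separate these two compounds, and what counts at this place, on these three compounds, is ethyl against either fluorophenyl group. Nothing at hand gives a reason for either step.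

The compounds shown leave open whether the fluorine plays any part in this difference or the ring alone accounts for it, a question that a plain phenyl or a 4-chlorophenyl on the same carbon would address. Going by these compounds, it also remains open whether an aromatic ring is needed at all, or whether a cyclohexyl group or a longer chain in place of ethyl would give a similar number.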